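The source may report more compounds than this note shows. Statements on the series, on what has been measured and on what is new or still open speak of the compounds shown alone.

In a functional assay on MCF7 cells (Homo sapiens) for cytotoxicity, read by sulforhodamine B assay (on this read-out lower numbers stand for higher toxicity in this test and higher numbers for lower toxicity in this test), two compounds sharing one core have been read so far. Compound 1 `CC1=CC[C@@H]([C@@](C)(O)CCCC(C)(C)NC(=S)N/N=C\c2ccccc2[N+](=O)[O-])CC1` gives only a limit, > 100000 nM. Among the compounds with values here, compound 2 `CC1=CC[C@@H]([C@@](C)(O)CCCC(C)(C)NC(=S)N/N=C\c2cccc(Cl)c2)CC1` gives 45900 nM, the only actual number available. Its standing can be judged only against compound 1. Compound 3 `CC1=CC[C@@H]([C@@](C)(O)CCCC(C)(C)NC(=S)N/N=C\c2ccc(Cl)cc2)CC1` keeps the same core and differs from compound 2 in one place: 4-chlorophenyl in place of 3-chlorophenyl on a carbon with a double bond to nitrogen. The two have the same atoms, joined differently. Within the data shown here, the one measured step, an at least 2.1-fold lower number from compound 1 to compound 2 (0.33 log units; beyond the scatter), bears on this only loosely. It also changes the group on a carbon with a double bond to nitrogen, but it replaces 2-nitrophenyl with 3-chlorophenyl, and one end of it is a limit. Among the measured compounds shown here, no measured step shows what happens when 4-chlorophenyl takes the place of 3-chlorophenyl. With only an at least 2.1-fold lower number from compound 1 to compound 2 (0.33 log units; beyond the scatter) as a guide, and that for a different exchange, no change beyond the scatter is expected in this assay, in either direction. The expected size is a 1.0-fold lower number from compound 2 to compound 3 (0.01 log units; within the scatter). For compound 3 the estimated value is 45000 nM, with an expected range from 20000 nM to 100000 nM.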

Compound 3, concentration lethal to 50% of the cells: 44300 nM
For compound 3 the middle estimate is 1.0-fold (0.01 log units) above the measured one; low and high end bracket the measured number.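

In this assay, the exchange of 3-chlorophenyl for 4-chlorophenyl on a carbon with a double bond to nitrogen gives a 1.0-fold lower number from compound 2 to compound 3 (0.02 log units; within the scatter), so these two chlorophenyl groups cannot be told apart at this place in this assay. The second chlorophenyl group also separates from 2-nitrophenyl, with an at least 2.2-fold lower number from compound 1 to compound 3 (0.35 log units; beyond the scatter), and the difference seen earlier with 3-chlorophenyl is thus not confined to that one group. Compound 1 enters both comparisons only as a limit, not as a number: the limit of > 100000 nM in this assay, at which 1 of the 3 values shown sits.

The compounds shown leave open whether phenyl without a substituent, 2-chlorophenyl, or 4-methoxyphenyl on that carbon would read like compound 2 and compound 3, and whether 3-nitrophenyl or 4-nitrophenyl would read like them or like compound 1. They also leave open the full size of the difference between the 2-nitrophenyl group and the chlorophenyl groups, and whether that difference comes with the loss of the nitro group or the arrival of the chlorine.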